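Chloro for Bromo on a Fused Ring in Two Cores

A few compounds are considered here, and "the series" means these few. Any claim that something is new, unique, unknown or untested is made for them only; others in the source may bear on it.

Three compounds were measured in a functional assay on cells (Cancer cell lines, Homo sapiens) for cytotoxicity, read by sulforhodamine B assay, with a stated time of 48 h; a higher number here means a weaker inhibitor of growth, a lower number a stronger inhibitor of growth:

Compound 1 `COc1ccc(C2=NN(C3=NC(=O)/C(=C4\C(=O)Nc5ccc(Br)cc54)S3)C(c3ccc(OC)cc3)C2)cc1`: 32500 nM
Compound 2 `COc1ccc(C2=NN(C3=NC(=O)/C(=C4\C(=O)Nc5ccc(Cl)cc54)S3)C(c3ccc(OC)cc3)C2)cc1`: 21200 nM
Compound 3 `COc1ccc(-c2cc(-c3ccc(Cl)cc3)n(C3C(=O)Nc4ccc(Br)cc43)n2)cc1`: 28700 nM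

Compound 1 and compound 2 share one core, and compound 3 carries another; the difference between the two cores is not broken down here. Within the first core, the change chloro in place of bromo on an aromatic carbon gave a 1.5-fold lower number from compound 1 to compound 2 (0.19 log units; within the scatter), so compound 1 and compound 2 are within the scatter of each other. Compound 3 stands within the scatter of both, its value lying closest to that of compound 1.

Compound 4 `COc1ccc(-c2cc(-c3ccc(Cl)cc3)n(C3C(=O)Nc4ccc(Cl)cc43)n2)cc1` is the not yet measured partner of compound 3, made by chloro in place of bromo on an aromatic carbon. The place is described in the same words as for the pair of compound 1 and compound 2, so it is the same change, now on the second core. Within the data shown here, the step is expected to be a 1.5-fold lower number from compound 3 to compound 4 (0.17 log units; within the scatter), resting on the single earlier step of a 1.5-fold lower number from compound 1 to compound 2 (0.19 log units; within the scatter) in this assay, which was within the scatter. Compound 4 is therefore estimated at 19500 nM in this assay, with an expected range from 9000 nM to 45000 nM.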

Compound 4, concentration for total growth inhibition: 14700 nM
The estimate for compound 4 lay 1.3-fold (0.12 log units) above the measured number, and the stated range covers the measured number.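

In this assay, chloro in place of bromo on an aromatic carbon gave a 2.0-fold lower number from compound 3 to compound 4 (0.29 log units; within the scatter), and this step can be set beside the one on the other core: the same change on two cores in this assay, a 1.5-fold lower number (0.19 log units; within the scatter) from compound 1 to compound 2 and a 2.0-fold lower number (0.29 log units; within the scatter) from compound 3 to compound 4, 1.3-fold (0.11 log units) apart, within the scatter of two such steps. The change therefore carried from the core of compound 1 to the core of compound 3 with no difference between the two steps that stands out from the scatter. Each step, however, lies within the scatter itself, so these two pairs do not show that the exchange alters growth inhibition on either core, and they set no rule for other cores in the series.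

The compounds shown hold only bromo or chloro on that aromatic carbon, so it remains open how an amine or a carboxylic acid in the same place would read in this assay. Going by these compounds, it is also open whether the same exchange would give a similar step if a longer chain stood on the amide nitrogen.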